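The source may hold more compounds than are shown below. What is called first, only, known or untested is meant among the compounds shown, and "the series" means these compounds.

Measured so far:
- compound 1 `CC1(C)N=C(N)N=C(N)N1c1ccc(OCCCCNC(=O)Nc2cccc(S(=O)(=O)F)c2)c(Cl)c1`: 7.7
- compound 2 `CC1(C)N=C(N)N=C(N)N1c1ccc(OCc2cccc(Cl)c2S(=O)(=O)F)c(Cl)c1`: 7.42

In an assay on isolated protein for inhibition of Dihydrofolate reductase (Mus musculus) (on this read-out lower numbers stand for lower potency and higher numbers for higher potency (the scale is a negative logarithm)), compound 1 holds the higher of the two numbers, yet compound 2 lies only a little lower, and that gap is within the scatter, so the two compounds are not separated by this read-out. For the measured compounds named here, no pair of measured compounds differs in one place, so no measured step is available to guide the next comparison.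

Compound 3 `CC1(C)N=C(N)N=C(N)N1c1ccc(OCCCCNC(=O)c2ccc(S(=O)(=O)F)cc2)c(Cl)c1` remains to be measured in this assay. Against compound 1 the change is 4-(fluorosulfonyl)phenyl in place of (3-(fluorosulfonyl)phenyl)amino on a carbonyl carbon. The part that leaves carries one hydrogen-bond donor; the part that enters carries none, and the fluorosulfonyl group moves from the 3-position of the ring to the 4-position as named. Going by the values given here, with no comparable measured step on record, the size of the step is uncertain; the expectation is a modest move, a number 0.30 log units lower from compound 1 to compound 3 (within the scatter), downward rather than upward, and possibly not beyond the scatter. Compound 3 is therefore estimated at 7.4 in this assay, with a plausible range from 6.8 to 8.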

Compound 3, logarithm of the reciprocal of the active concentration, log(1/C): 7.66
Compound 3: the middle estimate sits 0.26 log units below what was measured; measured number inside the range.
By their numbers in this assay, from the lowest: compounds 2, 3 and 1 (each within the scatter of the next).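

In this assay, for the compounds shown here, the step of a number 0.04 log units lower from compound 1 to compound 3 (within the scatter) comes with 4-(fluorosulfonyl)phenyl in place of (3-(fluorosulfonyl)phenyl)amino on a carbonyl carbon, and it is the first comparison that differs in one place. This read-out does not separate the two groups at this place, although the leaving part carries a hydrogen-bond donor, the entering part carries none, and the fluorosulfonyl group is named at a different ring position. No measured evidence is available to account for this result.

Going by these compounds, the step changes the hydrogen-bond donor and the ring position of the fluorosulfonyl group together, so it remains open whether either change alone would leave the number in the same place. Also open, on these data alone, is whether a nitrile or a carboxylic acid in place of the fluorosulfonyl group, or a longer chain in the linker, would give a step beyond the scatter in this assay on the core of compound 3.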